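Removing the Tolyl Methyl: What to Expect for Compound 3

A few compounds are considered here, and "the series" means these few. Any claim that something is new, unique, unknown or untested is made for them only; others in the source may bear on it.

Compound 1, `COc1ccc(-c2cc(/C=C/C(=O)c3ccc(C)cc3)nc3cc(-c4ccccc4)nn23)cc1OC`, gives 19800 nM in a functional assay on MDA-MB-231 cells (Homo sapiens) for antiproliferative activity, read by MTT assay, with a stated time of 24 h; on this read-out lower numbers stand for stronger inhibition and higher numbers for weaker inhibition.
Compound 2, `COc1cc(-c2cc(/C=C/C(=O)c3ccc(C)cc3)nc3cc(-c4ccccc4)nn23)cc(OC)c1OC`, gives 23900 nM in this assay.

Only these two compounds have measured numbers. Compound 1 holds the lowest of the two, and its nearest neighbour is compound 2; the step of a 1.2-fold higher number from compound 1 to compound 2 (0.08 log units; within the scatter) lies within the scatter, so the two compounds cannot be placed in any order on this read-out.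

Compound 3, `COc1ccc(-c2cc(/C=C/C(=O)c3ccccc3)nc3cc(-c4ccccc4)nn23)cc1OC`, has not yet been measured. It differs from compound 1 by hydrogen in place of methyl on an aromatic carbon. Among the compounds with values here, no measured step touches this part of the molecule: the only step available, a 1.2-fold higher number from compound 1 to compound 2 (0.08 log units; within the scatter), concerns a methoxy group and is a different kind of change altogether. There is therefore nothing in the measured pair that argues for a shift beyond the scatter in either direction, and the most reasonable reading is that the number stays close to that of compound 1.

The number for compound 3 in this assay is expected to be 20000 nM, with a range from 8000 nM to 50000 nM. This estimate means a step of a 1.0-fold higher number from compound 1 to compound 3 (0.00 log units; within the scatter), which is expected to remain within the scatter.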

Compound 3, half-maximal inhibitory concentration: 11800 nM
Estimate against measurement, compound 3: 1.7-fold (0.23 log units) above, within the range that was stated.
By their numbers in this assay, from the lowest: compounds 3, 1 and 2 (each within the scatter of the next, the first and the last beyond it).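

In this assay, within the data shown here, the change from 4-methylphenyl to phenyl gives a 1.7-fold lower number from compound 1 to compound 3 (0.22 log units; within the scatter) and is the first measured step at this position, since the only earlier step concerned a methoxy group on the other side of the molecule. It shows that the methyl, a single carbon on an aromatic carbon para to a large group, can be exchanged for hydrogen without a shift beyond the scatter, so the benzoyl and (4-methylphenyl)carbonyl forms cannot be placed in any order on this read-out. Nothing available explains the size of this step or links it to any feature of the methyl group.

The compounds shown leave open whether any other group on this same aromatic carbon, such as a chlorine atom, a methoxy group, an amine or a carboxylic acid, would move the number beyond the scatter. They also leave open whether the same exchange of methyl for hydrogen would give a similar step on the core of compound 2, which carries the additional methoxy group.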